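The source may hold more compounds than are shown below. What is called first, only, known or untested is meant among the compounds shown, and "the series" means these compounds.

Measured compounds: compound 1 `CCC(=O)N1CC2CC(C1)N2` at 5900 nM and compound 2 `CCCC(=O)N1CC2CC(C1)N2` at 850 nM, both in an assay on SH-EP1 cells for agonist activity at Neuronal acetylcholine receptor; alpha4/beta2 (Homo sapiens), read by FLIPR and calcium flux; a higher number here means that more compound is needed for the effect, a lower number that less compound is needed.

Compound 2 gives the lowest of the two numbers; its nearest neighbour, compound 1, sits a step away of a 6.9-fold lower number from compound 1 to compound 2 (0.84 log units; beyond the scatter). Compound 3 `O=C(CC1C=CCC1)N1CC2CC(C1)N2` carries cyclopent-2-en-1-yl in place of ethyl on a saturated chain carbon bound to a carbonyl carbon. Within the data shown here, the only step that bears on it is the chain extension from compound 1 to compound 2, where a larger acyl group lowered the number beyond the scatter. A further enlargement is therefore expected to lower the number again, though more weakly, so compound 3 is estimated at 400 nM (range 100 nM to 2000 nM), a step of a 2.1-fold lower number from compound 2 to compound 3 (0.33 log units; beyond the scatter) expected from compound 2.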

Compound 3, half-maximal effective concentration: 37000 nM
The estimate for compound 3 lay 93-fold (1.97 log units) below the measured number, and the stated range ends below it.
By their numbers in this assay, from the lowest: compound 2; then compound 1; then compound 3.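

In this assay, enlarging the group at this place does not keep lowering the number: cyclopent-2-en-1-yl in place of ethyl on a saturated chain carbon bound to a carbonyl carbon reverses the direction (a 44-fold higher number from compound 2 to compound 3 (1.64 log units; beyond the scatter)). The ring also carries the number past that of the smaller compound 1 (a 6.3-fold higher number from compound 1 to compound 3 (0.80 log units; beyond the scatter)), so size alone does not order these compounds. Nothing available accounts for this reversal.

The compounds shown leave open whether the ring, its double bond or the carbon count governs the rise. A saturated cyclopentyl group or a longer open chain such as pentyl on that carbon would separate these readings.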